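This account rests on a few compounds, and the source may have more. Where it says the series, first, only, none or still open, it means among the compounds named here.

Compound 1, `Cc1cccc(Cn2c(CN3CCN(C(=O)C4CCCC4)CC3)nc3ccccc32)c1`, was measured in an assay on isolated protein for inhibition of aldehyde dehydrogenase 1A1 (Homo sapiens), read by spectrophotometry, tested at 10 uM (a lower number here means less inhibition, a higher number more inhibition at the concentration tested (going by the name of the read-out)), and gave 67.5%. Among the three measured compounds it stands second highest: compound 2, `CC(C)=CCn1c(CN2CCN(C(=O)C3CC3)CC2)nc2ccccc21`, gave 74.3%, within the scatter of compound 1, while compound 3, `O=C(C1CC1)N1CCN(Cc2nc3ccccc3n2Cc2ccc(C(F)(F)F)cc2)CC1`, gave 37%, well below. Going by the values given here, the one step that differs in a single place is a number 37.3 percentage points lower from compound 2 to compound 3 (beyond the scatter), and it concerns the group on the saturated chain carbon bound to the aromatic nitrogen, not the amide end of the molecule.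

Compound 4, `Cc1cccc(Cn2c(CN3CCN(C(=O)C(C)C)CC3)nc3ccccc32)c1`, is not yet measured. It differs from compound 1 by isopropyl in place of cyclopentyl on a carbonyl carbon. Among the compounds with values here, no measured pair changes the group on that carbonyl carbon, so nothing in the data speaks directly to this change; the measured step from compound 2 to compound 3 does not bear on it. A small group replaces a five-membered ring, and the expectation is a step that is at most modest, a number 7.5 percentage points lower from compound 1 to compound 4 (within the scatter), with a downward lean but possibly within the scatter. Compound 4 is therefore estimated at 60%, in the range 40% to 78%.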

Compound 4, a percentage reported as inhibition, at one concentration (the size of the read-out at that concentration, not a potency): 87.2%
Compound 4: middle estimate off by 27.2 percentage points, on the low side; measured number above the stated range.
By their numbers in this assay, from the lowest: compound 3; then compounds 1 and 2 (each within the scatter of the next); then compound 4.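

Within this assay, the group on the carbonyl carbon proves to be a position that can move the read-out, which no earlier pair could show: isopropyl in place of cyclopentyl gives a number 19.7 percentage points higher from compound 1 to compound 4 (beyond the scatter) and lifts compound 4 clear of compound 1. The higher number comes with the smaller group, as 5 heavy atoms in a ring give way to 3 heavy atoms with no ring, while both groups are carbon only and carry no hydrogen-bond donors or acceptors. Nothing available explains this step.

Still open, as far as these compounds go, is whether the number depends on the ring, the size of the group or both, which a methyl, a tert-butyl or a phenyl on that carbonyl carbon would help to separate. From the compounds shown here alone, it is also open whether the same change gives a similar step with a different group on the saturated chain carbon bound to the aromatic nitrogen.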